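From methyl to fluoro: compound 3 to compound 4

This account rests on a few compounds, and the source may have more. Where it says the series, first, only, none or still open, it means among the compounds named here.

Measured in a functional assay on MT4 cells (Homo sapiens), read by MTT assay; a higher number here means that more compound is tolerated, a lower number that less compound is tolerated:
compound 1 `C#C[C@]1(CO)OC(N2C=CC(N)NC2=O)[C@@H](O)[C@@H]1O`: 1740 nM
compound 2 `C#C[C@]1(CO)O[C@@H](n2cc(Cl)c(=O)[nH]c2=O)C[C@@H]1O`: 81700 nM
compound 3 `C#C[C@]1(CO)O[C@@H](n2cc(C)c(N)nc2=O)C[C@@H]1O`: 700 nM

Compound 3 has the lowest number of the three, and its gaps to compound 1 and compound 2 both lie beyond the scatter. Compound 4 `C#C[C@]1(CO)O[C@@H](n2cc(F)c(N)nc2=O)C[C@@H]1O` has fluoro in place of methyl on an aromatic carbon. Among the compounds with values here, no measured pair differs in one place, so the size of this change remains unmeasured. The estimate therefore starts from compound 3 at 700 nM. A small step toward a lower number is expected in this assay, estimated as a 2.3-fold lower number from compound 3 to compound 4 (0.37 log units; beyond the scatter). For compound 4 the estimated value is 300 nM, with an expected range of 60 nM to 1500 nM.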

Compound 4, half-maximal cytotoxic concentration: > 100000 nM
Compound 4: no number, only a limit (the forecaster's own chance of this, stated with the estimate: 3%); middle value at least 330-fold (2.52 log units) away from the limit.
By their numbers in this assay, from the lowest: compound 3; then compound 1; then compound 2. At a limit, above all of these: compound 4.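

In this assay, fluoro in place of methyl on an aromatic carbon ortho to an amino group gives an at least 140-fold higher number from compound 3 to compound 4 (2.15 log units; beyond the scatter), the only single-place step shown and the first direct sign that this position strongly affects the tolerated concentration. For compound 4, > 100000 nM is a limit of the assay, not a number. The step is therefore a bound, and its full size is unknown: the limit of > 100000 nM in this assay, at which 1 of the 4 values shown sits.

On these data alone, whether the shift follows from losing methyl or from gaining fluoro remains open. Bromo or ethyl at this position on the core of compound 3 would help separate the two.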